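The source may report more compounds than this note shows. Statements on the series, on what has been measured and on what is new or still open speak of the compounds shown alone.

Compound 1 `CC(=O)Nc1cccc(C2CCN(CCCn3c(-c4ccccc4)nc4ccccc43)CC2)c1` gives 2 nM in an assay for displacement of a labelled ligand from melanin-concentrating hormone receptor 1 (Homo sapiens), read by fluorescence; on this read-out higher numbers stand for weaker inhibition and lower numbers for stronger inhibition. Compound 2 `CC(=O)Nc1cccc(C2CCN(CCCn3c(-c4ccccc4Cl)nc4ccccc43)CC2)c1` gives 10 nM. Compound 3 `CC(=O)Nc1cccc(C2CCN(CCCn3c(-c4cccc(C(F)(F)F)c4)nc4ccccc43)CC2)c1` gives 30 nM.

Compound 1 stands lowest of the three, the nearest being compound 2 at a 5.0-fold higher number from compound 1 to compound 2 (0.70 log units; beyond the scatter) and the furthest compound 3 at a 15-fold higher number from compound 1 to compound 3 (1.18 log units; beyond the scatter). Compound 4 `CC(=O)Nc1cccc(C2CCN(CCCn3c(-c4ccc(Br)cc4)nc4ccccc43)CC2)c1` differs from compound 1 by bromo in place of hydrogen on an aromatic carbon. Both measured steps that bear on it add a group to the same ring: the step from compound 1 to compound 2 is modest, the step from compound 1 to compound 3 large. Compound 4 is therefore expected to show a modest rise in this assay, a 4.0-fold higher number from compound 1 to compound 4 (0.60 log units; beyond the scatter). The estimate for compound 4 is 8 nM, with a range from 3 nM to 25 nM.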

Compound 4, half-maximal inhibitory concentration: 5 nM
Compound 4: middle estimate off by 1.6-fold (0.20 log units), on the high side, within the range that was stated.
By their numbers in this assay, from the lowest: compound 1; then compounds 4 and 2 (each within the scatter of the next); then compound 3.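

In this assay, the 4-bromophenyl group shows that one bromine para to a large group carries only a modest cost (a 2.5-fold higher number from compound 1 to compound 4 (0.40 log units; beyond the scatter)), and the unsubstituted phenyl of compound 1 keeps the lowest number. This substitution cannot be separated from the 2-chlorophenyl group (a 2.0-fold lower number from compound 2 to compound 4 (0.30 log units; within the scatter)), but it stands clear of the 3-(trifluoromethyl)phenyl group (a 6.0-fold lower number from compound 3 to compound 4 (0.78 log units; beyond the scatter)). No evidence on the cause of these differences is available.

Each substituted ring differs in both group and place, so the two effects remain unseparated. On these data alone, how an amine, a methoxy or a carboxylic acid would read at this place remains open.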